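The source may report more compounds than this note shows. Statements on the series, on what has been measured and on what is new or still open speak of the compounds shown alone.

Series notes. Compound 3 `COc1ccc2c(=O)c(/C=C/C(=O)NCc3ccccc3)coc2c1` carries a benzyl group on the amide-type nitrogen of its side chain. In a functional assay on HeLa cells (Homo sapiens) for inhibition, read by MTT assay, with a stated time of 48 h (a higher number here means a weaker inhibitor, a lower number a stronger inhibitor), compound 3 gives 33400 nM. Compound 1 `COc1ccc2c(=O)c(/C=C/C(=O)Nc3cccc(Cl)c3)coc2c1`, with 3-chlorophenyl on that nitrogen, gives 11900 nM in this assay. Compound 2 `O=C(/C=C/c1coc2cc(O)ccc2c1=O)NCc1ccccc1`, with hydrogen in place of methyl on an oxygen on the aromatic ring, is reported only as a limit of > 100000 nM in this assay. Among the numbers known, compound 3 stands highest; its nearest neighbour is compound 1, and the step of a 2.8-fold higher number from compound 1 to compound 3 (0.45 log units; beyond the scatter). The step of an at least 2.9-fold lower number from compound 2 to compound 3 (0.47 log units; beyond the scatter) runs against (the limit of > 100000 nM in this assay, at which 1 of the 3 values shown sits), so its size is known only as a bound.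

Compound 4 `COc1ccc2c(=O)c(/C=C/C(=O)Nc3cc(C)ccc3C)coc2c1` differs from compound 3 in one place: 2,5-dimethylphenyl in place of benzyl on an amide-type nitrogen. Among the compounds with values here, the one measured step bearing on this change is a 2.8-fold higher number from compound 1 to compound 3 (0.45 log units; beyond the scatter), which moved from a ring joined directly to the amide nitrogen to a benzyl group; compound 4 returns to a ring joined directly to that nitrogen, so a reversal of roughly that size, toward a lower number in this assay, is expected. Within the data shown here, no measured pair shows how 2,5-dimethylphenyl compares with 3-chlorophenyl. Compound 4 is expected to give 14000 nM in this assay, within an estimated range from 5000 nM to 45000 nM. This estimate implies the expected step of a 2.4-fold lower number from compound 3 to compound 4 (0.38 log units; beyond the scatter).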

Compound 4, half-maximal inhibitory concentration: 58400 nM
Estimate against measurement, compound 4: 4.2-fold (0.62 log units) below, outside the stated range (above it).
By their numbers in this assay, from the lowest: compound 1; then compounds 3 and 4 (each within the scatter of the next). At a limit, above all of these: compound 2.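

Replacing benzyl with 2,5-dimethylphenyl on the amide-type nitrogen gives a 1.7-fold higher number from compound 3 to compound 4 (0.24 log units; within the scatter), so in this assay these two groups are not separated, and joining the ring directly to that nitrogen does not by itself move the number beyond the scatter. The comparison between the two groups whose rings are joined directly to that nitrogen gives a 4.9-fold higher number from compound 1 to compound 4 (0.69 log units; beyond the scatter), which shows that the group on the ring matters here, and that the gain seen with 3-chlorophenyl does not carry over to every such ring. Among the three amide-nitrogen groups on the methoxy-bearing compounds, 3-chlorophenyl alone stands apart from the other two, while benzyl and 2,5-dimethylphenyl sit together; nothing at hand gives a measured property that would account for this difference between the groups.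

The compounds shown do not tell whether the chlorine itself, its place on the ring or the absence of the two methyl groups sets compound 1 apart, and an unsubstituted phenyl group would be the plain reference for that question. As far as these compounds go, it also stays open how this nitrogen responds to a ring carrying an amine or a carboxylic acid, or to a longer chain between the ring and the nitrogen.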